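This account rests on a few compounds, and the source may have more. Where it says the series, first, only, none or still open, it means among the compounds named here.

Two compounds in this small set already carry a result. Compound 1 `O=C(N[C@@H]1CNCC[C@H]1c1ccc(Cl)cc1)c1ccc(-c2ncnc3c2CCC3O)s1` was tested in an assay for inhibition of RAC-alpha serine/threonine-protein kinase (Homo sapiens), read by HTRF, with a stated time of 1 h; a higher number here means a weaker inhibitor, a lower number a stronger inhibitor; there compound 1 gives > 1000 nM, which is a limit of the assay rather than a measured number. Compound 2 `CC(=O)NCC[C@@H]1C[C@@H](c2ccc(F)c(F)c2)[C@H](NC(=O)c2cc(-c3c(Cl)cnn3C)c(Cl)o2)CN1` was tested as well, and in this assay compound 2 gives 2.49 nM. That makes compound 2 the holder of the only actual number shown, since the other value is the limit of > 1000 nM in this assay, at which 1 of the 2 values shown sits. For the measured compounds named here, no step between two measured compounds has been worked out, so nothing yet tells how much a single change in structure moves the result.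

Compound 3 `Cn1ncc(Cl)c1-c1cc(C(=O)N[C@@H]2CN[C@H](CCO)C[C@H]2c2ccc(F)c(F)c2)oc1Cl` has not been measured. It differs from compound 2 in one place: hydroxy in place of acetamido on a saturated chain carbon, two bonds along the chain from a saturated ring carbon. The acetamido group that leaves and the hydroxy group that enters both offer one hydrogen-bond donor and one acceptor, so the expectation is a step no larger than the usual scatter, and the estimated step is a 1.4-fold higher number from compound 2 to compound 3 (0.15 log units; within the scatter). Compound 3 is therefore expected to give 3.5 nM in this assay, with a range from 1.2 nM to 12 nM.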

Compound 3, half-maximal inhibitory concentration: 0.98 nM
Compound 3: the middle estimate sits 3.6-fold (0.55 log units) above what was measured; the whole stated range lies above it.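

For the compounds shown here, this is the first step in the set that can be read, and it shows that the chain at this position, a saturated chain carbon two bonds along from a saturated ring carbon, tolerates a large trim in this assay: going from 2-acetamidoethyl to 2-hydroxyethyl gives a 2.5-fold lower number from compound 2 to compound 3 (0.40 log units; beyond the scatter). The hydroxy group is much the smaller of the two yet has the same count of hydrogen-bond donors and acceptors, so in this pair the extra atoms of the acetamido group are not needed for strong inhibition, and the number even improves modestly. Nothing measured here accounts for why the number moves in this direction.

This single pair gives the size of one change at one position, and it cannot show whether the same swap would act alike on a different core. It also leaves open how an amine, a carboxylic acid, a methoxy group or a longer chain ending in hydroxy would compare at this place, and whether the hydroxy group itself matters or a plain ethyl chain would serve as well.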